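The source may hold more compounds than are shown below. What is called first, only, known or untested is meant among the compounds shown, and "the series" means these compounds.

Measured in a functional assay on HeLa cells (Homo sapiens) for antiproliferative activity, read by CCK-8 assay, with a stated time of 72 h; on this read-out lower numbers stand for stronger inhibition and higher numbers for weaker inhibition:
compound 1 `Nc1ccccc1NC(=O)c1ccc(Cn2cnc3c(Nc4ccccc4)nc(Cl)nc32)cc1`: 2920 nM
compound 2 `Nc1ccccc1NC(=O)c1ccc(Cn2cnc3c(NCc4ccccc4)nc(Cl)nc32)cc1`: 6770 nM
compound 3 `Nc1ccccc1NC(=O)c1ccc(Cn2cnc3c(Nc4ccc(-c5ccccn5)cc4)nc(Cl)nc32)cc1`: > 20000 nM, a limit of the assay

Of the two true numbers, the higher belongs to compound 2 at 6770 nM, while compound 1 gives 2920 nM. The entry for compound 3 is a limit and not a number.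

Compound 4 `CN1CCN(c2nc(Cl)nc3c2ncn3Cc2ccc(C(=O)Nc3ccccc3N)cc2)CC1` differs from compound 2 in one place, with 4-methylpiperazin-1-yl in place of benzylamino on an aromatic carbon.

Two measured steps change the group at this same place. The first is a 2.3-fold higher number from compound 1 to compound 2 (0.37 log units; beyond the scatter), and the second is an at least 2.9-fold higher number from compound 2 to compound 3 (0.47 log units; beyond the scatter). Both run upward in this assay, and the second is only a bound, since it ends at a limit. Neither brings in a non-aromatic ring, so they offer only a loose guide to size and direction. The step of an at least 6.8-fold higher number from compound 1 to compound 3 (0.83 log units; beyond the scatter) makes the same comparison from compound 1. On this basis, a small upward move is expected in this assay, one that may not clear the usual scatter.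

The estimated step is a 1.3-fold higher number from compound 2 to compound 4 (0.12 log units; within the scatter).

For compound 4 the expected value is 9000 nM, with an estimated range from 2500 nM to 20000 nM.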

Compound 4, half-maximal inhibitory concentration: 1170 nM
Beside the measured number, compound 4's estimate is 7.7-fold (0.89 log units) above it; the measured number lies below the stated range.
By their numbers in this assay, from the lowest: compound 4; then compound 1; then compound 2. At a limit, above all of these: compound 3.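

In this assay, among these compounds, compound 1, compound 2 and compound 3 all hold an aromatic ring of carbon only in the group at this place, and compound 4 is the first to hold a six-membered non-aromatic ring there, with a clear drop in the number: a 5.8-fold lower number from compound 2 to compound 4 (0.76 log units; beyond the scatter). The same group also gives a lower number than anilino, a 2.5-fold lower number from compound 1 to compound 4 (0.40 log units; beyond the scatter), so compound 4 stands lowest among the three compounds with true numbers. Thus this aromatic carbon, next to the ring nitrogen, does not need an aromatic ring of carbon only in its group, nor a hydrogen-bond donor, for the number to fall, since 4-methylpiperazin-1-yl has neither.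

Because the ring type, the donor and the second ring nitrogen all change together in compound 4, the compounds shown cannot say which of them counts, and a piperidin-1-yl, a morpholin-4-yl or an unmethylated piperazin-1-yl group at this place would be needed to pull these apart. Nothing measured here bears on what lies behind the drop in the number.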